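A fluorinated partner for compound 3 in cytotoxicity

This account rests on a few compounds, and the source may have more. Where it says the series, first, only, none or still open, it means among the compounds named here.

Among three compounds assessed in a functional assay on OVCAR-4 cells (Homo sapiens) for cytotoxicity, read by sulforhodamine B assay, with a stated time of 48 h, tested at 10 uM (on this read-out higher numbers stand for a weaker effect at the one concentration tested and lower numbers for a stronger effect), compound 3 `COc1ccc(C(=O)/C=C/c2cc(-c3cc(OC)c(OC)c(OC)c3)n[nH]2)cc1` gives -7%, which places it second highest of the three. Compound 1 `COc1cc(-c2cc(/C=C/C(=O)c3ccc(N)cc3)[nH]n2)cc(OC)c1OC` gives -22%, and compound 2 `COc1ccc(C(=O)/C=C/c2cc(-c3cc(OC)c(OC)c(OC)c3)n[nH]2)cc1OC` gives 23%. The group on the carbonyl carbon has been exchanged before within this small set: a number 45 percentage points higher from compound 1 to compound 2 (beyond the scatter), a number 30 percentage points lower from compound 2 to compound 3 (beyond the scatter), and a number 15 percentage points higher from compound 1 to compound 3 (beyond the scatter). Within the data shown here, compound 4 `COc1cc(-c2cc(/C=C/C(=O)c3ccc(F)c(F)c3)[nH]n2)cc(OC)c1OC` differs from compound 3 as follows. 3,4-difluorophenyl in place of 4-methoxyphenyl on a carbonyl carbon No measured compound carries fluorine, so the direction of this change is uncertain; earlier exchanges at the same place moved the read-out by modest to large amounts in both directions. A small step is therefore expected, a number 7 percentage points higher from compound 3 to compound 4 (within the scatter), likely within the scatter. Compound 4 is estimated at 0%, with an expected range from -30% to 30%.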

Compound 4, a percentage reported as activity, at one concentration (the size of the read-out at that concentration, not a potency): 17%
For compound 4 the middle estimate is 17 percentage points below the measured one, and the stated range covers the measured number.
By their numbers in this assay, from the lowest: compound 1; then compound 3; then compounds 4 and 2 (each within the scatter of the next).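

In this assay the 3,4-difluorophenyl group gives a number 24 percentage points higher from compound 3 to compound 4 (beyond the scatter) and a number 39 percentage points higher from compound 1 to compound 4 (beyond the scatter) while, against 3,4-dimethoxyphenyl, it gives a number 6 percentage points lower from compound 2 to compound 4 (within the scatter) so this read-out does not separate the two groups. Both disubstituted phenyl groups thus carry a weaker effect at this carbonyl carbon than 4-methoxyphenyl and 4-aminophenyl. Nothing available here accounts for this result.

Open, from the compounds shown here alone, is whether the second substituent alone sets this read-out, as 4-fluorophenyl or 3,4-dichlorophenyl on the same carbonyl carbon could show.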